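Methyl extensions on a shared pyrrolopyrimidine thioether series

The compounds below may be only part of what the source reports. "The series", "measured", "known", "first", "only" and "open" are said of these compounds alone.

Compound 1 `COc1cc(Cl)c(-c2nc(SCC(=O)NC3CC3)nc3[nH]cc(C#N)c23)cc1OC` is the reference point of this set. In a functional assay on BT-474 cells (Homo sapiens) for antiproliferative activity, read by sulforhodamine B assay, with a stated time of 4 days (a lower number here means a stronger inhibitor of growth, a higher number a weaker inhibitor of growth), compound 1 gives 69 nM. Compound 2 `CCOc1cc(-c2nc(SCC(=O)NC3CC3)nc3[nH]cc(C#N)c23)c(Cl)cc1OC` carries one change, (methyl in place of hydrogen on a saturated chain carbon bound to an oxygen on an aromatic ring), and in this assay compound 2 gives 25 nM, a step of a 2.8-fold lower number from compound 1 to compound 2 (0.44 log units; beyond the scatter). Compound 3 `COc1cc(Cl)c(-c2nc(SCC(=O)NC(C)C)nc3[nH]cc(C#N)c23)cc1O` stands apart from compound 1 by a difference that is not broken down here, and in this assay compound 3 gives 161 nM, the highest number of the three. Compound 4 `COc1cc(Cl)c(-c2nc(SCC(=O)NC(C)(C)C)nc3[nH]cc(C#N)c23)cc1O` differs from compound 3 by methyl in place of hydrogen on a saturated chain carbon bound to an amide-type nitrogen and two saturated chain carbons. This is the same kind of change as that from compound 1 to compound 2, but the place differs: there the carbon was bound to an oxygen on an aromatic ring, here it is bound to an amide-type nitrogen and two saturated chain carbons. Because the earlier step of a 2.8-fold lower number from compound 1 to compound 2 (0.44 log units; beyond the scatter) sat at a different place, compound 4 is expected to move only modestly, with an estimated step of a 1.3-fold lower number from compound 3 to compound 4 (0.13 log units; within the scatter). Compound 4 is therefore expected to give about 120 nM in this assay, with a likely range from 45 nM to 320 nM.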

Compound 4, concentration for 50% growth inhibition: 128 nM
Compound 4: middle estimate off by 1.1-fold (0.03 log units), on the low side; the range from low to high includes it.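

In this assay, turning isopropyl into tert-butyl gives a 1.3-fold lower number from compound 3 to compound 4 (0.10 log units; within the scatter). Set beside the earlier methyl step, this one cannot be told apart from it: the same change on two cores in this assay, a 2.8-fold lower number (0.44 log units; beyond the scatter) from compound 1 to compound 2 and a 1.3-fold lower number (0.10 log units; within the scatter) from compound 3 to compound 4, 2.2-fold (0.34 log units) apart, within the scatter of two such steps. This is no proof that the change carries over from one core to another, as the methyl sits at a different place in each pair and each place is represented by one pair only.

The compounds shown leave open what a longer chain or an amine in place of the tert-butyl group would do in this assay. They also leave open whether either methyl step would hold at its own place on the other core.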